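The source may report more compounds than this note shows. Statements on the series, on what has been measured and on what is new or still open speak of the compounds shown alone.

Measured compounds in an assay on Sf9 cells for inhibition of activin receptor type-1 (Homo sapiens), read by HTRF, with a stated time of 3 h, in the presence of a further agent that is not named here; on this read-out higher numbers stand for weaker inhibition and lower numbers for stronger inhibition:
compound 1, `COC(=O)N1C[C@@H](C)N(c2ncc3[nH]nc(-c4ccc(N5CCN[C@H](C)C5)nc4)c3n2)[C@@H](C)C1`, gives 0.85 nM;
compound 2, `C[C@@H]1CN(c2ccc(-c3n[nH]c4cnc(N5[C@H](C)CN(C(=O)N(C)C)C[C@@H]5C)nc34)cn2)CCN1`, gives 6.4 nM;
compound 3, `C[C@@H]1CN(c2ccc(-c3n[nH]c4cnc(N5CCCCC5)nc34)cn2)CCN1`, gives 40 nM.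

Compound 1 holds the lowest of the three numbers. The nearest to it is compound 2, reached by a 7.5-fold higher number from compound 1 to compound 2 (0.88 log units; beyond the scatter), and compound 3 stands furthest from it. The unmeasured compound 4, `C[C@@H]1CN(c2ccc(-c3n[nH]c4cnc(N5[C@H](C)CNC[C@@H]5C)nc34)cn2)CCN1`, differs from compound 1 in one place: hydrogen in place of methoxycarbonyl on an amine nitrogen in a ring. For the measured compounds named here, no measured step removes this group outright. Going by the values given here, the one step that touches the same carbonyl carbon, a 7.5-fold higher number from compound 1 to compound 2 (0.88 log units; beyond the scatter), shows that merely exchanging the substituent on it moved the number beyond the scatter, and compound 3, which bears no methoxycarbonyl group, gives a number far higher than compound 1. Compound 4 is therefore expected to give a higher number than compound 1, by a 12-fold higher number from compound 1 to compound 4 (1.07 log units; beyond the scatter), though the size of this step is uncertain. The estimated value of compound 4 in this assay is 10 nM, with a range from 2 nM to 50 nM.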

Compound 4, half-maximal inhibitory concentration: 793 nM
Compound 4: the middle estimate sits 79-fold (1.90 log units) below what was measured; measured number outside the range, above it.
By their numbers in this assay, from the lowest: compound 1; then compound 2; then compound 3; then compound 4.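

In this assay, removing the methoxycarbonyl group from this ring nitrogen has a large effect, with a 930-fold higher number from compound 1 to compound 4 (2.97 log units; beyond the scatter), and removing the dimethylcarbamoyl group likewise gives a 120-fold higher number from compound 2 to compound 4 (2.09 log units; beyond the scatter), so both substituted compounds stand far lower than the one bearing hydrogen there, and none of the compounds shown goes against this. The 2,6-dimethylpiperazin-1-yl group with hydrogen on this nitrogen also fares worse than the plain piperidin-1-yl group, with a 20-fold higher number from compound 3 to compound 4 (1.30 log units; beyond the scatter), so the bare ring is worse here than a ring lacking this nitrogen altogether. No measurement given here accounts for these steps.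

The compounds shown leave open whether a carbonyl is needed on this nitrogen at all, or whether a methyl, an acetyl or a methanesulfonyl group would also restore the low number.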